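This account rests on a few compounds, and the source may have more. Where it says the series, first, only, none or still open, it means among the compounds named here.

Compound 2, `O=C(O)CCC[C@@H]1CC[C@@H]2[C@@H](/C=C/[C@@H](O)COc3ccccc3)[C@H](O)C[C@@H]2OC1`, gives the lower of the two numbers measured in a functional assay on CHO cells for agonist activity at prostaglandin E2 receptor EP3 subtype (Homo sapiens), read by fluorescence and calcium flux (a higher number here means that more compound is needed for the effect, a lower number that less compound is needed), at 2.3 nM; compound 1, `O=C(O)CC[C@H]1CC[C@@H]2[C@@H](/C=C/[C@@H](O)COc3ccccc3)[C@H](O)C[C@@H]2OC1`, gives 4800 nM in this assay. Compound 3, `O=C(O)CCC[C@H]1CC[C@@H]2[C@@H](/C=C/[C@@H](O)COc3ccccc3)[C@H](O)C[C@@H]2OC1`, differs from compound 2 in configuration only: the two compounds have the same atoms and bonds and differ only in configuration as drawn: 1 of 7 stereo elements differ; a stereocentre at a saturated ring carbon is drawn R in compound 2 and S in compound 3. For the measured compounds named here, no pair measured so far isolates this inversion, and the two known numbers lie far apart for a pair that differs in more than this. An inversion at a ring stereocentre is expected to cost potency in this assay, with a step from compound 2 to compound 3 estimated at a 130-fold higher number from compound 2 to compound 3 (2.12 log units; beyond the scatter). Compound 3 is therefore expected at about 300 nM, within 20 nM to 4000 nM.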

Compound 3, half-maximal effective concentration: 4 nM
For compound 3 the middle estimate is 75-fold (1.88 log units) above the measured one, outside the stated range (below it).
By their numbers in this assay, from the lowest: compounds 2 and 3 (each within the scatter of the next); then compound 1.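

The pair isolates this one stereocentre: the fact that compounds 2 and 3 differ only in the configuration as drawn. In this assay, the inversion from R to S at this saturated ring carbon gives a 1.7-fold higher number from compound 2 to compound 3 (0.24 log units; within the scatter), so the two configurations cannot be told apart here. The large gap instead goes with the chain, with carboxymethyl in place of carboxy on a saturated chain carbon accompanying a 1200-fold lower number from compound 1 to compound 3 (3.08 log units; beyond the scatter). Still open, as far as these compounds go, is how a longer chain ending in the carboxylic acid, or a primary amide in place of that acid, would read in this assay. From the compounds shown here alone, whether the inversion would be equally silent on the shorter chain of compound 1 also stays open.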